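Ethyl carbonate in place of cinnamate on the quinoline ester chain

The compounds below may be only part of what the source reports. "The series", "measured", "known", "first", "only" and "open" are said of these compounds alone.

Compound 1 `CSc1cnc2ccccc2c1[Se]CC#CCOC(=O)c1ccc(C(=O)O)cc1`: 3.1 ug/mL
Compound 2 `CSc1cnc2ccccc2c1SCC#CCOC(=O)/C=C/c1ccccc1`: 9.4 ug/mL
Compound 3 `C#CCSc1cnc2ccccc2c1SCC#CCOC(=O)/C=C/c1ccccc1`: 14.7 ug/mL

In a functional assay on B16 cells (Mus musculus) for antiproliferative activity, with a stated time of 72 h (on this read-out higher numbers stand for weaker inhibition and lower numbers for stronger inhibition), compound 2 gives the second highest of the three numbers; its nearest neighbour is compound 3, and compound 1 lies furthest away with a lower number beyond the scatter. Compound 4 `CCOC(=O)OCC#CCSc1c(SC)cnc2ccccc12` is not yet measured. It differs from compound 2 in one place: ethoxy in place of 2-phenylethenyl on a carbonyl carbon.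

Within the data shown here, the only measured step, a 1.6-fold higher number from compound 2 to compound 3 (0.19 log units; within the scatter), concerns a different place on the shared core and lies within the scatter, so it gives no direct guide to swapping the group on the carbonyl carbon. Compound 1 shows a lower number, but it differs from compound 2 in more than one place, so its value cannot be tied to this change alone. With nothing bearing directly on the swap, the expected step for a 1.3-fold higher number from compound 2 to compound 4 (0.11 log units; within the scatter) is none beyond the scatter. Compound 4 is therefore estimated at 12 ug/mL, within a range from 5 ug/mL to 30 ug/mL.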

Compound 4, concentration for 50% inhibition: 5.5 ug/mL
For compound 4 the middle estimate is 2.2-fold (0.34 log units) above the measured one; the range from low to high includes it.
By their numbers in this assay, from the lowest: compounds 1, 4, 2 and 3 (each within the scatter of the next, the first and the last beyond it).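

Among these compounds, on the carbonyl carbon, the step from 2-phenylethenyl to ethoxy in this assay gives a 1.7-fold lower number from compound 2 to compound 4 (0.23 log units; within the scatter) and so offers the first direct reading at this position. A group with a six-membered aromatic ring and a double bond gives way to a smaller one with neither, and the two compounds still cannot be told apart in this test, so neither the ring nor that double bond is needed here for a number in this range. Nothing measured here explains this result. 

Among the compounds shown here, this single step covers only two groups at this position, so it cannot show a trend with size or shape. Going by these compounds, whether an amine, a longer chain such as butoxy, or a benzyloxy group on the same carbonyl carbon would also stay within the scatter of compound 2 remains open.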